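Piperidine substitution in the sulfonyl-anilide series: compound 4

The source may report more compounds than this note shows. Statements on the series, on what has been measured and on what is new or still open speak of the compounds shown alone.

Working notes on the series. Three compounds carry numbers in a functional assay on OVCAR-3 cells (Homo sapiens) for activation, with a stated time of 24 h; on this read-out higher numbers stand for an effect only at larger amounts of compound and lower numbers for an effect already at smaller amounts. Compound 1 `O=C(Nc1cccc(S(=O)(=O)C2CCCC2)n1)c1ccc(NCCO)cc1N1CCC2(CC1)CC2` gives 177 nM. Compound 2 `O=C(Nc1cccc(S(=O)(=O)C2CCCC2)c1)c1cccnc1N1CCCCC1` gives 6350 nM. Compound 3 `O=C(Nc1cccc(S(=O)(=O)C2COC2)c1)c1cccnc1N1CCC2(CC1)CC2` gives 14800 nM. Compound 2 stands second highest of the three: compound 3 sits above it by a gap beyond the usual scatter, and compound 1 lies far below it, also beyond the scatter. Going by the values given here, no two measured compounds differ in a single place, so no single-point step is available as a guide.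

Compound 4 `CC1(C)CCN(c2ncccc2C(=O)Nc2cccc(S(=O)(=O)C3CCCC3)c2)CC1` is not yet measured. It differs from compound 2 as follows: 4,4-dimethylpiperidin-1-yl in place of piperidin-1-yl on an aromatic carbon The ring itself is kept; only the two methyl groups on the 4,4-dimethylpiperidin-1-yl are added.

Among the compounds with values here, with no comparable step among the measured compounds, the expectation for this change is a small one, and no step beyond the scatter is expected in this assay: the expected move is a 1.3-fold lower number from compound 2 to compound 4 (0.10 log units; within the scatter). Compound 4 is therefore estimated at 5000 nM, with a range from 1800 nM to 15000 nM.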

Compound 4, half-maximal effective concentration: 2720 nM
Compound 4: the middle estimate sits 1.8-fold (0.26 log units) above what was measured, and the stated range covers the measured number.
By their numbers in this assay, from the lowest: compound 1; then compound 4; then compound 2; then compound 3.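

In this assay, going by these compounds alone, the change to 4,4-dimethylpiperidin-1-yl in place of piperidin-1-yl gives a 2.3-fold lower number from compound 2 to compound 4 (0.37 log units; beyond the scatter) and is the only step that compares compounds differing in one place. This position, on an aromatic carbon next to the ring nitrogen and ortho to a large group, therefore accepts the two added methyl groups with no loss on this read-out, and the number moves in the favourable direction by a modest amount. Nothing measured here bears on the reason for this step.

The compounds shown leave open whether a group other than these two piperidines, such as morpholine or a piperidine carrying a hydroxyl or a primary amine, would be accepted at this position. They also leave open whether the same step would appear on the core of compound 1, which carries the 2-aminoethanol-derived side chain.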